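The compounds below may be only part of what the source reports. "The series", "measured", "known", "first", "only" and "open" are said of these compounds alone.

Values in a functional assay on cells (Cancer cell lines, Homo sapiens) for inhibition; a higher number here means a weaker inhibitor of growth, a lower number a stronger inhibitor of growth:
- compound 1 `Cc1cc(-c2nc3sc(C)cn3c2/C=N/NC(=N)N)c(C)s1`: 11700 nM
- compound 2 `Cc1cn2c(/C=N/NC(=N)N)c(-c3ccsc3)nc2s1`: 20400 nM
- compound 3 `N=C(N)N/N=C/c1c(-c2cccs2)nc2sccn12`: 24000 nM
- compound 4 `Cc1cn2c(/C=N/NC(=N)N)c(-c3cccs3)nc2s1`: not yet measured

Compound 3 and compound 2 lie within the scatter of each other. Compound 3 reads a higher number than compound 1, and that gap lies just beyond the scatter.

Compound 4 is compound 3 with methyl in place of hydrogen on an aromatic carbon, next to the ring sulfur: methyl in place of hydrogen on an aromatic carbon.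

Among the measured compounds shown here, no measured step tests this change directly. For the measured compounds named here, the one measured step, a 1.7-fold higher number from compound 1 to compound 2 (0.24 log units; within the scatter), puts thiophen-3-yl in place of 2,5-dimethylthiophen-3-yl elsewhere on the molecule, and it stays within the scatter. Compound 2 already carries the methyl on the shared core and reads 20400 nM, which is level with compound 3 within the scatter, although the two also differ in how the thiophene is attached. No shift beyond the scatter is therefore expected in this assay.

The estimated step is a 1.2-fold lower number from compound 3 to compound 4 (0.08 log units; within the scatter). For compound 4 the expected value is 20000 nM, with an expected range of 11000 nM to 36000 nM.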

Compound 4, concentration for total growth inhibition: 8130 nM
Estimate against measurement, compound 4: 2.5-fold (0.39 log units) above; measured number below the stated range.
By their numbers in this assay, from the lowest: compounds 4, 1, 2 and 3 (each within the scatter of the next, the first and the last beyond it).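

In this assay, among the compounds shown here, methyl in place of hydrogen on an aromatic carbon, next to the ring sulfur, gives a 3.0-fold lower number from compound 3 to compound 4 (0.47 log units; beyond the scatter), the first direct reading at this position, and it shows that the position matters when thiophen-2-yl is present. With that methyl held on the core, the thiophene also matters: thiophen-2-yl in place of thiophen-3-yl gives a 2.5-fold lower number from compound 2 to compound 4 (0.40 log units; beyond the scatter), while thiophen-2-yl in place of 2,5-dimethylthiophen-3-yl gives only a 1.4-fold lower number from compound 1 to compound 4 (0.16 log units; within the scatter) and so separates the two compounds by no more than the scatter. No measurement at hand accounts for these steps.

Going by these compounds, whether the methyl step carries over to compounds bearing thiophen-3-yl remains open. Also open, on these data alone, is how a longer chain, an amine or a carboxylic acid would read at this position.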